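This account rests on a few compounds, and the source may have more. Where it says the series, first, only, none or still open, it means among the compounds named here.

Compound 1, `O=C1Nc2ccccc2/C1=N/NC(=S)Nc1ccccc1`, and compound 2, `O=C1Nc2ccc(Cl)cc2/C1=N/NC(=S)Nc1ccccc1`, share one core and differ in a single chloro in place of hydrogen on an aromatic carbon. In an ADME assay on RD cells (Homo sapiens) for cytotoxicity (a lower number here means that less compound is tolerated, a higher number that more compound is tolerated), compound 1 gives only a limit of the assay, > 25000 nM. In this assay compound 2 likewise gives only a limit, > 25000 nM. The step that the two limits leave unreadable from compound 1 to compound 2 therefore cannot be read in size, since both of its values sit at the limit of > 25000 nM in this assay, at which 2 of the 2 values shown sit.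

Compound 3, `O=C1Nc2ccc(Br)cc2/C1=N/NC(=S)Nc1ccccc1`, carries bromo in place of chloro on an aromatic carbon. Going by the values given here, only the step from compound 1 to compound 2 bears on this change, and it is unreadable because of the limit of > 25000 nM in this assay, at which 2 of the 2 values shown sit. Among the compounds with values here, no measured step points to a shift beyond the scatter for this assay. Compound 3 is therefore expected to sit at the same limit in this assay, an estimated step that the limit leaves unreadable from compound 2 to compound 3. The estimate for compound 3 is 30000 nM, within a range from 15000 nM to 60000 nM.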

Compound 3, half-maximal cytotoxic concentration: > 25000 nM
Compound 3: no number, only a limit (the forecaster's own chance of this, stated with the estimate: 75%); the middle value does not contradict the limit.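

In this assay compound 3 also gives only a limit, so the steps linking compound 1, compound 2 and compound 3 cannot be read in size: the limit of > 25000 nM in this assay, at which 3 of the 3 values shown sit. The compounds shown leave open at what concentration each becomes cytotoxic, and whether hydrogen, chloro or bromo on that aromatic carbon makes any difference.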